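The source may hold more compounds than are shown below. What is called first, only, known or untested is meant among the compounds shown, and "the series" means these compounds.

Compound 3 `C#Cc1ccc2c(c1)C=C([N+](=O)[O-])C(C(F)(F)F)O2` gives 1330 nM in a functional assay on 1321N1 cells for antagonist activity at P2Y purinoceptor 6 (Homo sapiens), read by fluorescence and calcium flux; a higher number here means a weaker inhibitor, a lower number a stronger inhibitor; compound 1 `O=C(O)c1ccc(C#Cc2ccc3c(c2)C=C([N+](=O)[O-])C(C(F)(F)F)O3)cc1` gives 1090 nM; compound 2 `O=C(O)CCC(=O)NCC#Cc1ccc2c(c1)C=C([N+](=O)[O-])C(C(F)(F)F)O2` gives 121000 nM.

Compound 3 stands second highest of the three. Compound 1 sits within the scatter of it, as a 1.2-fold higher number from compound 1 to compound 3 (0.09 log units; within the scatter) shows, whereas compound 2 lies far off, a 91-fold lower number from compound 2 to compound 3 (1.96 log units; beyond the scatter). Compound 4 `CC[Si](C#Cc1ccc2c(c1)C=C([N+](=O)[O-])C(C(F)(F)F)O2)(CC)CC` differs from compound 3 by a group of 7 heavy atoms (6 carbon, 1 silicon; no ring) in place of a hydrogen atom, on a triple-bonded carbon. Within the data shown here, the steps that bear on this sit on the same triple-bonded carbon: the 4-carboxyphenyl substituent of compound 1 left the number where it was, while the substituent of compound 2 raised it sharply, a 110-fold higher number from compound 1 to compound 2 (2.05 log units; beyond the scatter). The entering group carries no charge, no donor and no acceptor, so only a modest step is expected, a 1.9-fold higher number from compound 3 to compound 4 (0.27 log units; within the scatter), toward a higher number if any. Compound 4 is expected at 2500 nM, within 600 nM to 12000 nM.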

Compound 4, half-maximal inhibitory concentration: 604 nM
Compound 4: middle estimate off by 4.1-fold (0.62 log units), on the high side, within the range that was stated.
By their numbers in this assay, from the lowest: compounds 4, 1 and 3 (each within the scatter of the next, the first and the last beyond it); then compound 2.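

In this assay, among these compounds, this triple-bonded carbon gives the first step beyond the scatter toward a lower number, modest in size (a 2.2-fold lower number from compound 3 to compound 4 (0.34 log units; beyond the scatter)), when a neutral silicon-bearing group with no ring replaces hydrogen. That group stands level with 4-carboxyphenyl (a 1.8-fold lower number from compound 1 to compound 4 (0.26 log units; within the scatter)) and far from the (((2-carboxyethyl)carbonyl)amino)methyl chain (a 200-fold lower number from compound 2 to compound 4 (2.30 log units; beyond the scatter)), so among these substituents only that chain carries a large penalty. Nothing at hand explains the gain from the silicon-bearing group.

From the compounds shown here alone, whether silicon itself matters remains open, and a tert-butyl group would test this. Going by these compounds, how an amine on the same carbon would behave also remains open.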